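The source may hold more compounds than are shown below. What is called first, only, known or untested is meant among the compounds shown, and "the series" means these compounds.

Measured so far in a functional assay on A549 cells (Homo sapiens) for cytotoxicity; on this read-out lower numbers stand for stronger inhibition and higher numbers for weaker inhibition:
Compound 1 `O=C1NC(c2ccc(Br)cc2)CN1S(=O)(=O)c1ccc2c(c1)CCC2` gives 33900 nM
Compound 2 `Cc1ccc(C2CN(S(=O)(=O)c3ccc(Cl)cc3)C(=O)N2)cc1` gives 158000 nM

Compound 1 holds the lower of these two numbers, and the gap up to compound 2 lies beyond the scatter. Compound 3 `Cc1ccc(C2CN(S(=O)(=O)c3ccc4c(c3)CCC4)C(=O)N2)cc1` has not yet been measured. It keeps the core of compound 1 and differs in one place (methyl in place of bromo on an aromatic carbon), with methyl in place of bromo on an aromatic carbon, para to a large group. Among the measured compounds shown here, no measured pair isolates this change. Compound 2 also carries the 4-methylphenyl group, but it differs elsewhere too, so its value of 158000 nM is only a loose guide. In this assay a small step toward a higher number is therefore expected, not clearly beyond the scatter. The expected step is a 1.8-fold higher number from compound 1 to compound 3 (0.25 log units; within the scatter) on this estimate. For compound 3 the estimated value is 60000 nM with an expected range from 25000 nM to 150000 nM as its bounds.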

Compound 3, half-maximal inhibitory concentration: 99200 nM
Beside the measured number, compound 3's estimate is 1.7-fold (0.22 log units) below it; the measured number falls inside the stated range.
By their numbers in this assay, from the lowest: compound 1; then compounds 3 and 2 (each within the scatter of the next).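

In this assay, among the compounds shown here, this is the first pair to isolate the group on an aromatic carbon, para to a large group: with the rest of the structure unchanged, going from 4-bromophenyl to 4-methylphenyl gives a 2.9-fold higher number from compound 1 to compound 3 (0.47 log units; beyond the scatter). The position therefore responds to an exchange of one heavy atom for another, with a modest step toward weaker inhibition that lies beyond the usual scatter. Nothing available explains this step.

The compounds shown carry only bromo and methyl at this position, so it remains open how an amine, a methoxy group or a carboxylic acid would read there. As far as these compounds go, it is also open whether the same exchange would give a similar step with the rest of the molecule changed, for example with the sulfonyl group of compound 2.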